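Ester variation on a shared core: cytotoxicity notes

This account rests on a few compounds, and the source may have more. Where it says the series, first, only, none or still open, it means among the compounds named here.

Measured compounds in an ADME assay on Vero cells (Chlorocebus sabaeus) for cytotoxicity, read by MTT assay, with a stated time of 48 h; a higher number here means a weaker inhibitor, a lower number a stronger inhibitor:
- compound 1 `CCCC(=O)OC1CCC(CN2CCN(c3cc(=O)c4cc(C(F)(F)F)cc([N+](=O)[O-])c4s3)CC2)CC1`: > 64 ug/mL, a limit of the assay
- compound 2 `O=C(OC1CCC(CN2CCN(c3cc(=O)c4cc(C(F)(F)F)cc([N+](=O)[O-])c4s3)CC2)CC1)c1cccc(C(F)(F)F)c1`: > 64 ug/mL, a limit of the assay
- compound 3 `Cc1ccc(C(=O)OC2CCC(CN3CCN(c4cc(=O)c5cc(C(F)(F)F)cc([N+](=O)[O-])c5s4)CC3)CC2)cc1`: > 64 ug/mL, a limit of the assay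

Compound 3 stands at a limit only; no number is available for it in this assay. The same holds across the set, because of the limit of > 64 ug/mL in this assay, at which 3 of the 3 values shown sit. Accordingly the three steps among the measured compounds carry no readable size: a step that the two limits leave unreadable from compound 1 to compound 2, a step that the two limits leave unreadable from compound 1 to compound 3 and a step that the two limits leave unreadable from compound 2 to compound 3. All three describe exchanges of the group on the carbonyl carbon of the ester, and none moved the read-out off the limit.

The next compound, compound 4 `COc1cccc(C(=O)OC2CCC(CN3CCN(c4cc(=O)c5cc(C(F)(F)F)cc([N+](=O)[O-])c5s4)CC3)CC2)c1`, changes the same position: 3-methoxyphenyl in place of 4-methylphenyl on a carbonyl carbon.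

Of the measured steps, all three bear on this change, since each alters the group on the carbonyl carbon, and each was unreadable. No listed evidence separates any of these esters from one another in this assay. The expectation is therefore a step of no readable size, with compound 4 most probably again sitting at the limit.

For compound 4 the estimate in this assay is 100 ug/mL, with a range from 50 ug/mL to 250 ug/mL. The step this estimate implies is expected to be a step that the limit leaves unreadable from compound 3 to compound 4.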

Compound 4, half-maximal inhibitory concentration: > 64 ug/mL
Compound 4 gave a limit, no number (the forecaster's own chance of this, stated with the estimate: 85%); the middle value does not contradict the limit.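

No step from compound 1, compound 2 or compound 3 to compound 4 can be read in this assay, because every value is a limit and not a number: the limit of > 64 ug/mL in this assay, at which 4 of the 4 values shown sit.

The compounds shown leave open whether the group on the carbonyl carbon affects the read-out in this assay at all, and how far any of these four esters lies from the limit.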